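Ester variation in a Rho kinase 2 inhibitor series

The compounds below may be only part of what the source reports. "The series", "measured", "known", "first", "only" and "open" are said of these compounds alone.

Compound 1 `COC(=O)c1cccc(-c2cc(C(=O)Nc3ccncc3)ccc2CN)c1` is the reference point; in an assay on isolated protein for inhibition of Rho-associated protein kinase 2 (Homo sapiens), read by radiometric assay (a higher number here means a weaker inhibitor, a lower number a stronger inhibitor), compound 1 gives 2.9 nM. Compound 2 `COC(=O)c1cccc(-c2cc(C(=O)Nc3ccncc3F)ccc2CN)c1` carries fluoro in place of hydrogen on an aromatic carbon and gives 7.8 nM; the step is a 2.7-fold higher number from compound 1 to compound 2 (0.43 log units; beyond the scatter). Compound 3 `NCc1ccc(C(=O)Nc2ccncc2F)cc1-c1cccc(C(=O)Oc2ccccc2)c1` has phenyl in place of methyl on an oxygen next to a carbonyl group and gives 6.2 nM; the step is a 1.3-fold lower number from compound 2 to compound 3 (0.10 log units; within the scatter). Among the three measured compounds compound 3 holds the second highest number: its value and that of compound 2 lie within the scatter of each other, while compound 1 sits beyond the scatter with the lower number.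

Compound 4 `NCc1ccc(C(=O)Nc2ccncc2F)cc1-c1cccc(C(=O)OCC2CCCCO2)c1` differs from compound 3 at the same oxygen: (oxan-2-yl)methyl in place of phenyl on an oxygen next to a carbonyl group. Among the measured compounds shown here, the only measured step that bears on this oxygen is a 1.3-fold lower number from compound 2 to compound 3 (0.10 log units; within the scatter), where a change of the ester group kept the number within the scatter. On that single precedent, no step beyond the scatter is expected from compound 3 to compound 4, in either direction; the estimated step is a 1.0-fold lower number from compound 3 to compound 4 (0.01 log units; within the scatter). For the measured compounds named here, compound 4 is therefore expected to give about 6 nM, with a range from 2.5 nM to 15 nM, the width reflecting that only one earlier change at this oxygen has been measured.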

Compound 4, half-maximal inhibitory concentration: 12 nM
Compound 4: the middle estimate sits 2.0-fold (0.30 log units) below what was measured, and the stated range covers the measured number.
By their numbers in this assay, from the lowest: compound 1; then compounds 3, 2 and 4 (each within the scatter of the next).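

In this assay the oxygen next to the carbonyl group now carries three different groups on the fluoro-bearing core, and the non-aromatic (oxan-2-yl)methyl group reads like the aromatic phenyl and the small methyl: the data give a 1.9-fold higher number from compound 3 to compound 4 (0.29 log units; within the scatter) and a 1.5-fold higher number from compound 2 to compound 4 (0.19 log units; within the scatter). Compounds 2, 3 and 4 therefore cannot be placed in any order, so across this set neither the loss of the aromatic ring nor the entry of a hydrogen-bond acceptor on the ester group has a readable effect on the number. No evidence is at hand that bears on this result.

The compounds shown leave open whether the ring oxygen of the (oxan-2-yl)methyl group matters at all, a question that cyclohexylmethyl at the same place would address, and whether the same group reads alike on the core of compound 1, which lacks the fluoro group. On these data alone, all four compounds carry an ester here, so how a carboxylic acid or a primary amide at this carbonyl group would read also remains open.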